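Replacing a bicyclic group with trifluoromethylphenyl

The source may report more compounds than this note shows. Statements on the series, on what has been measured and on what is new or still open speak of the compounds shown alone.

Of the compounds shown here, three built on a shared core have been tested in a functional assay on DLD-1 cells (Homo sapiens) for cytotoxicity, read by colorimetric assay and MTT assay, with a stated time of 3 days, tested at 1 uM; a higher number here means a weaker effect of the compound at the concentration tested, a lower number a stronger effect. Compound 1 `COc1ccc(-n2cc(-c3ccccc3)c(-c3ccc4c(c3)NC(=O)CO4)n2)cc1` gives 92.2%. Among the measured compounds shown here, compound 3 `O=C1COc2ccc(-c3nn(-c4cc(Cl)cc(Cl)c4)cc3-c3ccccc3)cc2N1` gives 90.3%; the step of a number 1.9 percentage points lower from compound 1 to compound 3 (within the scatter) is the only one-place change among the measured compounds. Compound 2 `O=C1COc2ccc(-c3[nH]c(-c4c[nH]c5ncccc45)nc3-c3ccccc3)cc2N1` gives 97.7%. Compound 2 stands highest of the three numbers, but its distance to compound 1 and to compound 3 lies within the scatter, so no order among the three can be read, and all three show only a weak effect at the concentration tested.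

Compound 4 `O=C1COc2ccc(-c3[nH]c(-c4ccc(C(F)(F)F)cc4)nc3-c3ccccc3)cc2N1` differs from compound 2 in one place: a group of 10 heavy atoms (7 carbon, 3 fluorine; one six-membered aromatic ring of carbon only) in place of a group of 9 heavy atoms (7 carbon, 2 nitrogen; one five-membered aromatic ring with 1 hetero atom, one six-membered aromatic ring with 1 hetero atom), on an aromatic carbon. For the measured compounds named here, no measured step touches this position: the step from compound 1 to compound 3 changes a group on an aromatic nitrogen, not on the aromatic carbon between two ring nitrogen atoms, and that step was small anyway. Going by the values given here, with every measured number sitting close together and no step bearing on this change, the expectation for compound 4 is a number in the same region, with the step of a number 3.7 percentage points lower from compound 2 to compound 4 (within the scatter) expected to stay within the scatter. Compound 4 is therefore estimated at 94%, within a range from 80% to 105%.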

Compound 4, a percentage reported as activity, at one concentration (the size of the read-out at that concentration, not a potency): 95%
Compound 4: the middle estimate sits 1 percentage points below what was measured; the measured number falls inside the stated range.
By their numbers in this assay, from the lowest: compounds 3, 1, 4 and 2 (each within the scatter of the next).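

Among the compounds shown here, at the aromatic carbon between two ring nitrogen atoms, the result gives the first measured step at this position: in this assay, swapping the two-ring group for 4-(trifluoromethyl)phenyl gives a number 2.7 percentage points lower from compound 2 to compound 4 (within the scatter) and so leaves no readable difference between the two compounds. The group that leaves has a hydrogen-bond donor, a hydrogen-bond acceptor and ring nitrogen atoms, whereas the group that enters has none of these, so at this single concentration the compound with the two-ring group and the compound with the carbon-only ring cannot be told apart. No supporting evidence bears on this result.

Both compounds show only a weak effect at the tested concentration, so the step says little about how this position would behave in a compound with a clearly stronger effect. On these data alone, it remains open whether a much smaller or differently built group at this carbon, such as an amine, a carboxylic acid or a longer alkyl chain, would move the number beyond the usual scatter.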